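The source may hold more compounds than are shown below. What is called first, only, known or untested is meant among the compounds shown, and "the series" means these compounds.

In a functional assay on HeLa cells (Homo sapiens) for cytotoxicity, read by resazurin assay, with a stated time of 72 h (on this read-out lower numbers stand for stronger inhibition and higher numbers for weaker inhibition), compound 1 (`COCCSC(=S)SCC(=O)c1ccc(OC)cc1`) gives 7880 nM and compound 2 (`CCSC(=S)SCC(=O)c1cccc(NC(C)=O)c1`) gives 9380 nM while compound 3 (`CCSC(=S)SCC(=O)c1cccc(CNC(C)=O)c1`) gives 11300 nM in the same test. The number for compound 2 falls among the other two, but all three lie within the scatter of one another, so none of them stands apart.

Compound 4 (`CCSC(=S)SCC(=O)c1cccc(NC(=O)c2ccccc2)c1`) has not been measured yet. It keeps the structure of compound 2 except for one group, with phenyl in place of methyl on a carbonyl carbon, which reads as acetyl to benzoyl (phenyl in place of methyl on a carbonyl carbon).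

Among the measured compounds shown here, only one measured step offers any guide. Acetamidomethyl in place of acetamido on an aromatic carbon gave a 1.2-fold higher number from compound 2 to compound 3 (0.08 log units; within the scatter) and so did not move the number beyond the scatter. For the measured compounds named here, that step changed a different part of the molecule, and no measured step replaces this methyl with a ring, so the evidence is thin and the range must stay wide. No step beyond the scatter is therefore expected in this assay and neither direction is clearly favoured. The estimate amounts to a 1.2-fold lower number from compound 2 to compound 4 (0.07 log units; within the scatter) and should be read as no real change. Compound 4 is estimated at 8000 nM with an expected range from 3500 nM to 18000 nM around that figure.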

Compound 4, half-maximal inhibitory concentration: 8230 nM
For compound 4 the middle estimate is 1.0-fold (0.01 log units) below the measured one, within the range that was stated.
By their numbers in this assay, from the lowest: compounds 1, 4, 2 and 3 (each within the scatter of the next).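

In this assay, putting phenyl in place of methyl on the carbonyl carbon replaces 1 heavy atom with 6 and adds a six-membered aromatic ring, yet the result is only a small step (a 1.1-fold lower number from compound 2 to compound 4 (0.06 log units; within the scatter)). Among the compounds shown here, the one earlier step (a 1.2-fold higher number from compound 2 to compound 3 (0.08 log units; within the scatter)) changed a different part of the side group, so this is the first sign that the group on this carbonyl carbon can also be swapped, here for a much larger one, without the number leaving the scatter. Nothing measured here explains why the number stays within the scatter after so large a swap.

The compounds shown leave open whether a different kind of group on this carbonyl carbon, such as an amine, a carboxylic acid or a longer carbon chain, would move the number beyond the scatter. They also leave open whether this tolerance holds outside this single cell test, since a flat result here says nothing about how the same swap would behave on another read-out.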